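From Ethoxycarbonyl to Carboxy: Notes on Compound 4

This account rests on a few compounds, and the source may have more. Where it says the series, first, only, none or still open, it means among the compounds named here.

In a functional assay on a cell-free system (Platelet, plasma, Oryctolagus cuniculus) for inhibition, with a stated time of 5 min (a lower number here means a stronger inhibitor, a higher number a weaker inhibitor), compound 1 (`CCOC(=O)/C=C/c1ccc(OCc2nc(C)c(C)nc2C)cc1`) gives > 2000000 nM as its result, a limit of the assay and not a number. Compound 3 (`CCOC(=O)/C=C/c1cc(Br)cc(Br)c1OCc1nc(C)c(C)nc1C`) gives > 2000000 nM as its result, again a limit. Compound 1 therefore stands at the limit of > 2000000 nM in this assay, at which 2 of the 3 values shown sit, and has no measured number of its own. Compound 2 (`CCOC(=O)/C=C/c1ccc(OCc2nc(C)c(C)nc2C)c(O)c1`) gives a number (1380000 nM).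

Compound 4 (`Cc1nc(C)c(COc2ccc(/C=C/C(=O)O)cc2)nc1C`) carries hydrogen in place of ethyl on an oxygen next to a carbonyl group, which turns ethoxycarbonyl into carboxy. For the measured compounds named here, no measured step covers this change. The nearest is an at least 1.4-fold lower number from compound 1 to compound 2 (0.16 log units; that floor lies within the scatter) as hydroxy replaces hydrogen on an aromatic carbon, a different place on the molecule, so it offers only weak guidance. No step beyond the scatter is therefore expected in this assay, and the estimated step is an at least 1.1-fold lower number from compound 1 to compound 4 (0.04 log units; that floor lies within the scatter) with no firm direction. Compound 4 is estimated at 1800000 nM with an expected range from 600000 nM to 4000000 nM and a real chance of reaching only a limit of the assay.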

Compound 4, half-maximal inhibitory concentration: 1400000 nM
The estimate for compound 4 lay 1.3-fold (0.11 log units) above the measured number; measured number inside the range.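

In this assay, for the compounds shown here, the change from ethoxycarbonyl to carboxy gives an at least 1.4-fold lower number from compound 1 to compound 4 (0.15 log units; that floor lies within the scatter), the first reading for a change at this end of the molecule. Compound 1 gives > 2000000 nM, which is a limit of the assay and not a number. The step is therefore a floor that does not go beyond the scatter, and its real size stays unread, with the comparison resting on a limit: the limit of > 2000000 nM in this assay, at which 2 of the 4 values shown sit.

The compounds shown leave open whether an amide or a longer-chain ester in place of the carboxy group would give a step beyond the scatter. They also leave open what carboxy does when combined with the hydroxy group of compound 2 or the bromines of compound 3.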